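Aryl methyl to chloro swap in an amide series

The source may report more compounds than this note shows. Statements on the series, on what has been measured and on what is new or still open speak of the compounds shown alone.

Compound 1 `CCC(=O)N(c1ccc(Cl)cc1)C1CCCCC1N(C)C`: in a functional assay on the whole organism for positive allosteric modulation, with Mus musculus as the target (a higher number here means that more compound is needed for the effect, a lower number that less compound is needed), compound 1 gives 14 mg/kg.
Compound 2 `CCC(=O)N(c1ccc(C)cc1)C1CCCCC1N(C)C`: in this assay compound 2 reaches only a limit of the assay, > 50 mg/kg.
Compound 3 `CCC(=O)N(c1ccccc1C)C1CCCC1N(C)C`: in this assay compound 3 likewise reaches only a limit of the assay, > 50 mg/kg.

The change from compound 2 to compound 1 is chloro in place of methyl on an aromatic carbon. The step that goes with it is an at least 3.5-fold lower number from compound 2 to compound 1 (0.55 log units; beyond the scatter). Its size is known from one side only because of the limit of > 50 mg/kg in this assay, at which 2 of the 3 values shown sit.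

Compound 4 `CCC(=O)N(c1ccccc1Cl)C1CCCC1N(C)C` has not been measured. It differs from compound 3 by chloro in place of methyl on an aromatic carbon. This is the same kind of change as from compound 2 to compound 1, but not the same: there the chloro is para to a large group, here it is ortho to a large group. The difference between the cores of compound 2 and compound 3 is not broken down here.

For compound 4 a step of an at least 1.2-fold lower number from compound 3 to compound 4 (0.09 log units; that floor lies within the scatter) is expected. This rests on the step of an at least 3.5-fold lower number from compound 2 to compound 1 (0.55 log units; beyond the scatter), carried over to a core whose starting point is a limit. The spread of the expectation is wide for that reason. The estimate for compound 4 in this assay is 40 mg/kg, between 12 mg/kg and 150 mg/kg.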

Compound 4, dose for half-maximal effect: > 50 mg/kg
Compound 4 was reported as a limit (the forecaster's own chance of this, stated with the estimate: 50%); middle value at least 1.2-fold (0.09 log units) away from the limit.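

No step can be read from compound 3 to compound 4 in this assay, because both values are limits: the limit of > 50 mg/kg in this assay, at which 3 of the 4 values shown sit.

The compounds shown leave open whether chloro in place of methyl, ortho to a large group, changes the dose needed on the core of compound 3 at all, and by how much.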